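Ring amines on the shared core: piperidin-1-yl to pyrrolidin-1-yl

The source may hold more compounds than are shown below. What is called first, only, known or untested is meant among the compounds shown, and "the series" means these compounds.

Values in a functional assay on MGC-803 cells (Homo sapiens) for inhibition, read by sulforhodamine B assay; a lower number here means a stronger inhibitor, a higher number a weaker inhibitor:
- compound 1 `O=C1C=C(Nc2ccccc2F)C(=O)c2c1nc1n2[C@H]2OC[C@@H](O)[C@H]2OC1`: 2080 nM
- compound 2 `CCCN(CCC)C1=CC(=O)c2nc3n(c2C1=O)[C@H]1OC[C@@H](O)[C@H]1OC3`: > 16000 nM (a limit)
- compound 3 `O=C1C=C(N2CCCCC2)C(=O)c2c1nc1n2[C@H]2OC[C@@H](O)[C@H]2OC1`: > 8000 nM (a limit)

Compound 3 has no numerical value on this scale. Its > 8000 nM is a limit. Compound 2 also has only a limit, > 16000 nM. Compound 1 is the only one of the three with a measured number, 2080 nM.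

The next structural change leads to compound 4 `O=C1C=C(N2CCCC2)C(=O)c2c1nc1n2[C@H]2OC[C@@H](O)[C@H]2OC1`: pyrrolidin-1-yl in place of piperidin-1-yl on a double-bonded ring carbon. In words, this is pyrrolidin-1-yl in place of piperidin-1-yl on a double-bonded ring carbon.

The closest measured evidence is an at least 3.8-fold higher number from compound 1 to compound 3 (0.58 log units; beyond the scatter), where piperidin-1-yl replaces (2-fluorophenyl)amino. The change to dipropylamino points the same way: an at least 7.6-fold higher number from compound 1 to compound 2 (0.88 log units; beyond the scatter). Both steps lie beyond the scatter, but both start from the arylamino group, which compound 4 does not carry. Going by the values given here, the only measured step between two groups without that arylamino group is a step that the two limits leave unreadable from compound 2 to compound 3, so it gives no size to work from. No step beyond the scatter is therefore expected in this assay, and compound 4 is expected to resemble compound 3 rather than compound 1. The estimated change is a step that the limit leaves unreadable from compound 3 to compound 4. The estimate for compound 4 is 10000 nM, with an expected range from 4000 nM to 25000 nM.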

Compound 4, half-maximal inhibitory concentration: > 16000 nM
Compound 4: a limit, no number; the forecaster's own chance of this, stated with the estimate: 55%; middle value at least 1.6-fold (0.20 log units) away from the limit.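

Compound 4 in this assay gives > 16000 nM, which is a limit and not a number. Pyrrolidin-1-yl on the double-bonded ring carbon therefore joins piperidin-1-yl and dipropylamino as a third group with only a limit, so a five-membered ring, a six-membered ring and an open dialkylamino group all end the same way, and this limit recurs: the limit of > 16000 nM in this assay, at which 2 of the 4 values shown sit. Set against the (2-fluorophenyl)amino group, the new ring amine gives an at least 7.6-fold higher number from compound 1 to compound 4 (0.88 log units; beyond the scatter), which leaves compound 1 as the only one of the four compounds with a measured number.

The steps among compound 2, compound 3 and compound 4 cannot be read, as each of these compounds has only a limit, so no order among their three amino groups can be stated. Still open, from the compounds shown here alone, is whether the measurable activity of compound 1 depends on the aryl ring, on the fluorine or on the amino hydrogen, a question that an unsubstituted phenylamino group or a simple alkylamino group such as cyclohexylamino at this position would address.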